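A Benzyl Swap on the Weakest of Three Compounds

The source may report more compounds than this note shows. Statements on the series, on what has been measured and on what is new or still open speak of the compounds shown alone.

- compound 1 `COc1ccc(/C=C2\CN(Cc3cn(Cc4cccc(Cl)c4)nn3)C/C(=C\c3ccc(OC)cc3)C2=O)cc1`: 98000 nM
- compound 2 `O=C1/C(=C/c2ccccc2F)CN(Cc2cn(Cc3cccc(Cl)c3)nn2)C/C1=C\c1ccccc1F`: 12000 nM
- compound 3 `Cc1ccc(/C=C2\CN(Cc3cn(Cc4cccc(Cl)c4)nn3)C/C(=C\c3ccc(C)cc3)C2=O)cc1`: 9000 nM

All three compounds were tested in a functional assay on MDA-MB-231 cells (Homo sapiens) for cytotoxicity, read by MTT assay, with a stated time of 24 h; on this read-out higher numbers stand for weaker inhibition and lower numbers for stronger inhibition. Compound 1 gives the highest number of the three, and both compound 2 and compound 3 lie lower by more than the usual scatter, which makes compound 1 the weakest of the set.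

Compound 4 `COc1ccc(/C=C2\CN(Cc3cn(Cc4ccccc4F)nn3)C/C(=C\c3ccc(OC)cc3)C2=O)cc1` has not yet been measured. It keeps the rest of compound 1 and changes in one place: 2-fluorophenyl in place of 3-chlorophenyl on a saturated chain carbon bound to an aromatic nitrogen. In words, 2-fluorophenyl stands in place of 3-chlorophenyl on a saturated chain carbon bound to an aromatic nitrogen. The measured compounds all carry the 3-chlorobenzyl group, so none of them shows what this change does on its own.

Among the compounds with values here, with no direct precedent, only a rough expectation is possible in this assay. Compound 1, at 98000 nM, sits at the top of the measured range, so a moderate move towards a lower number seems more likely than a rise, although a step within the scatter remains possible. The expected change is a 2.0-fold lower number from compound 1 to compound 4 (0.29 log units; within the scatter). For compound 4 the estimated value is 50000 nM, with an expected range from 15000 nM to 130000 nM.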

Compound 4, half-maximal inhibitory concentration: 67200 nM
Beside the measured number, compound 4's estimate is 1.3-fold (0.13 log units) below it, and the stated range covers the measured number.
By their numbers in this assay, from the lowest: compounds 3 and 2 (each within the scatter of the next); then compounds 4 and 1 (each within the scatter of the next).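

In this assay, the move to 2-fluorophenyl in place of 3-chlorophenyl on a saturated chain carbon bound to an aromatic nitrogen gives a 1.5-fold lower number from compound 1 to compound 4 (0.16 log units; within the scatter), so the two compounds cannot be told apart on this read-out. The earlier compounds shown here all carry the 3-chlorobenzyl group, which made this the first view of that position, and here 2-fluorobenzyl serves as well as 3-chlorobenzyl with the rest of compound 1 held fixed. Nothing available accounts for this result or says what lies behind it.

This single pair changes the halogen and its place on the ring together, so neither change can be read alone, and it does not show whether the same swap would leave the number as little altered in the setting of compound 2 or compound 3. Also open, going by these compounds, is what a different kind of group would do at this place, such as an unsubstituted phenyl, or a longer chain ending in an amine or a carboxylic acid.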